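The source may hold more compounds than are shown below. What is called first, only, known or untested is meant among the compounds shown, and "the series" means these compounds.

- compound 1 `COc1ccc(-c2cc3ccccc3nc2/C=C/C(=O)c2ccc([N+](=O)[O-])cc2)cc1`: 6100 nM
- compound 2 `COc1ccc(-c2cc3ccccc3nc2/C=C/C(=O)c2cccs2)cc1`: 7030 nM
- compound 3 `COc1ccc(-c2cc3ccccc3nc2/C=C/C(=O)c2ccccn2)cc1`: 4140 nM

These values come from a functional assay on H184B5F5/M10 cells (Homo sapiens) for antiproliferative activity, read by XTT assay, with a stated time of 72 h; a higher number here means a weaker inhibitor, a lower number a stronger inhibitor. The three compounds share a core and differ only in the group on a carbonyl carbon. Compound 3, which carries pyridin-2-yl there, does not separate from the other two. The measured steps are a 1.5-fold lower number from compound 1 to compound 3 (0.17 log units; within the scatter), a 1.7-fold lower number from compound 2 to compound 3 (0.23 log units; within the scatter) and a 1.2-fold higher number from compound 1 to compound 2 (0.06 log units; within the scatter), so swapping this group has so far moved the number very little.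

Compound 4 `COc1ccc(-c2cc3ccccc3nc2/C=C/C(=O)c2cnc(N)nc2C)cc1` changes the same place: 2-amino-4-methylpyrimidin-5-yl in place of pyridin-2-yl on a carbonyl carbon. All three measured steps bear on this change, since each one exchanges the group on that carbonyl carbon. Within the data shown here, none of the measured groups carries an amino or a methyl group, however, so they offer no guide to direction. No step beyond the scatter is therefore expected in this assay, although the uncertainty is wide for a group not yet tried. The estimated step is a 1.2-fold higher number from compound 3 to compound 4 (0.08 log units; within the scatter). Compound 4 is estimated at 5000 nM, with an expected range of 1800 nM to 14000 nM.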

Compound 4, half-maximal inhibitory concentration: > 10000 nM
Compound 4: only a limit was reported; the forecaster's own chance of this, stated with the estimate: 12%; middle value at least 2.0-fold (0.30 log units) from the limit.
By their numbers in this assay, from the lowest: compounds 3, 1 and 2 (each within the scatter of the next). At a limit, above all of these: compound 4.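

In this assay compound 4 gives only a limit, > 10000 nM. Unlike the steps among compounds 1, 2 and 3, an at least 2.4-fold higher number from compound 3 to compound 4 (0.38 log units; beyond the scatter) lies beyond the scatter, so the group on this carbonyl carbon can matter after all, and 2-amino-4-methylpyrimidin-5-yl goes with a weaker result than pyridin-2-yl. The floors of an at least 1.4-fold higher number from compound 2 to compound 4 (0.15 log units; that floor lies within the scatter) and an at least 1.6-fold higher number from compound 1 to compound 4 (0.21 log units; that floor lies within the scatter) lie within the scatter, so compound 4 is clearly separated only from compound 3, and every step to it remains a minimum: the limit of > 10000 nM in this assay, at which 1 of the 4 values shown sits.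

The compounds shown leave open which part of 2-amino-4-methylpyrimidin-5-yl goes with the higher number: the amino group, the methyl group or the ring nitrogens. Also open, from the compounds shown here alone, is where a plain pyrimidin-5-yl or an unsubstituted phenyl group on this carbonyl carbon would fall in this assay.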